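Working notes: a shorter amino side chain

A few compounds are considered here, and "the series" means these few. Any claim that something is new, unique, unknown or untested is made for them only; others in the source may bear on it.

In a functional assay on MDA-MB-435 cells (Homo sapiens) for cytotoxicity, read by MTT assay, with a stated time of 72 h (a lower number here means a stronger inhibitor, a higher number a weaker inhibitor), compound 1 (`N[C@H]1CC[C@H](Nc2c(C(=O)NCc3ccco3)nc(Br)c3cccnc23)CC1`) gives > 10000 nM as a limit of the assay and not a number. Compound 2 (`CC(C)(C)OC(=O)N1CCN(c2c(C(=O)NCc3ccc(F)cc3)nc(Br)c3cccnc23)CC1`) gives 10000 nM here. Compound 3 (`CN(C)CCCNc1c(C(=O)NCc2ccc(F)cc2)nc(Br)c2cccnc12`) gives 7000 nM here, within the scatter of compound 2, so these two numbers do not separate.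

Compound 4 (`NCCNc1c(C(=O)NCc2ccc(F)cc2)nc(Br)c2cccnc12`) carries amino in place of (dimethylamino)methyl on a saturated chain carbon, two bonds along the chain from a nitrogen on an aromatic ring. Going by the values given here, no measured step of this kind is available, so no step beyond the scatter is expected in this assay in either direction. The expected step of a 1.2-fold lower number from compound 3 to compound 4 (0.07 log units; within the scatter) is estimated to stay small. For compound 4 the estimated value is 6000 nM with an expected range of 2500 nM to 10000 nM in this assay.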

Compound 4, half-maximal inhibitory concentration: 12000 nM
Compound 4: the middle estimate sits 2.0-fold (0.30 log units) below what was measured; the measured number lies above the stated range.
By their numbers in this assay, from the lowest: compounds 3, 2 and 4 (each within the scatter of the next).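

Going by these compounds alone, this is the first one-place comparison: going from (3-(dimethylamino)propyl)amino to (2-aminoethyl)amino gives a 1.7-fold higher number from compound 3 to compound 4 (0.23 log units; within the scatter) in this assay. At this position, then, shortening the chain and removing the dimethyl substitution together do not separate the two compounds. Compound 1 gives a limit of the assay and not a number: the limit of > 10000 nM in this assay, at which 1 of the 4 values shown sits.

Within the data shown here, the single step leaves open how chain length and the terminal amine each contribute. A (3-aminopropyl)amino or a (2-(dimethylamino)ethyl)amino side chain would separate the two changes.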